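Sulfonyl substituent changes in a BJ-cell antiproliferation series

The compounds below may be only part of what the source reports. "The series", "measured", "known", "first", "only" and "open" are said of these compounds alone.

Compound 1 `COc1ccc(-c2c(I)c(=O)c3c(OC)cc(OC)cc3n2S(=O)(=O)c2ccc(OC)cc2)cc1`: > 34400 nM
Compound 2 `COC(=O)c1cc(=O)c2c(OC)cc(OC)cc2n1C`: > 37900 nM
Compound 3 `COc1ccc(-c2cc(=O)c3c(OC)cc(OC)cc3n2S(=O)(=O)c2cccc([N+](=O)[O-])c2)cc1`: > 39600 nM

For the measured compounds named here, every value so far in an ADME assay on BJ cells (Homo sapiens) for antiproliferative activity, with a stated time of 72 h (a higher number here means that more compound is needed for the effect, a lower number that less compound is needed), is a limit of the assay rather than a number. Compound 3 stands at a limit, (the limit of > 39600 nM in this assay, at which 1 of the 3 values shown sits). Compound 1 also stands at a limit, (the limit of > 34400 nM in this assay, at which 1 of the 3 values shown sits). Compound 2 also stands at a limit, (the limit of > 37900 nM in this assay, at which 1 of the 3 values shown sits). Going by the values given here, no step between two measured compounds is available, so no measured change can anchor the next one.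

Compound 4 `COc1ccc(-c2cc(=O)c3c(OC)cc(OC)cc3n2S(=O)(=O)Cc2ccccc2)cc1` differs from compound 3 in one place: benzyl in place of 3-nitrophenyl on a sulfonyl sulfur. With nothing measured against which to weigh this change, the expected step is none beyond the scatter, and the limit is expected to persist. Compound 4 is estimated at 40000 nM, ranging from 15000 nM to 100000 nM. The expected step that the limit leaves unreadable from compound 3 to compound 4 is essentially flat.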

Compound 4, half-maximal effective concentration: > 34400 nM
Compound 4 gave a limit, no number; the forecaster's own chance of this, stated with the estimate: 80%; the middle value does not contradict the limit.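

For the compounds shown here, compound 3 and compound 4 both give limits in this assay, not numbers, so no step between them can be read. The compounds shown leave open whether any sulfonyl substituent yields a measurable value in this assay.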